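Swapping the oxadiazole substituent toward an anilino link

The source may hold more compounds than are shown below. What is called first, only, known or untested is meant among the compounds shown, and "the series" means these compounds.

Measured compounds:
- compound 1 `CCOc1ccc(Cc2nnc(CN(c3cccc(Cl)c3C)S(=O)(=O)c3ccc(C)cc3)o2)cc1`: 50.1 nM
- compound 2 `Cc1ccc(S(=O)(=O)N(Cc2nnc(Cc3c(Cl)cccc3Cl)o2)c2cccc(Cl)c2C)cc1`: 501 nM

Both were tested in a functional assay on CHO cells for antagonist activity at prostaglandin E2 receptor EP1 subtype (Homo sapiens), read by FLIPR and calcium flux; a higher number here means a weaker inhibitor, a lower number a stronger inhibitor. Going by the values given here, compound 2 holds the highest number of the two, and its nearest neighbour is compound 1 by a 10-fold higher number from compound 1 to compound 2 (1.00 log units; beyond the scatter), the one change being 2,6-dichlorophenyl in place of 4-ethoxyphenyl on a saturated chain carbon bound to an aromatic carbon. Compound 3 `COc1ccc(Nc2nnc(CN(c3cccc(Cl)c3C)S(=O)(=O)c3ccc(C)cc3)o2)cc1` has not been measured; it differs from compound 2 by (4-methoxyphenyl)amino in place of 2,6-dichlorobenzyl on an aromatic carbon. Among the compounds with values here, the only step known touches the same position and shows that a para-alkoxyphenyl-type arm, as in compound 1, sits at a lower number than the dichlorinated one. Since compound 3 carries a 4-methoxyphenyl arm, though joined through an amino nitrogen rather than a chain carbon, a downward move of about a 4.2-fold lower number from compound 2 to compound 3 (0.62 log units; beyond the scatter) is expected. Compound 3 is therefore estimated at 120 nM, with a range from 30 nM to 450 nM.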

Compound 3, inhibition constant: 79.4 nM
Estimate against measurement, compound 3: 1.5-fold (0.18 log units) above; measured number inside the range.
By their numbers in this assay, from the lowest: compounds 1 and 3 (each within the scatter of the next); then compound 2.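

In this assay, this position on the five-membered aromatic ring accepts an amino nitrogen as the link to the aryl arm: replacing 2,6-dichlorobenzyl with (4-methoxyphenyl)amino gives a 6.3-fold lower number from compound 2 to compound 3 (0.80 log units; beyond the scatter). Set against the 4-ethoxybenzyl arm, the same group gives a 1.6-fold higher number from compound 1 to compound 3 (0.20 log units; within the scatter), so these two arms cannot be told apart here, even though this swap alters the link and the alkoxy group together. Nothing at hand gives a reason for these numbers.

On these data alone, the aryl group and the link never vary alone in these compounds, so the share of each in the step from the dichlorinated arm remains unknown. A (2,6-dichlorophenyl)amino arm or a (4-ethoxyphenyl)amino arm would pull the two apart, and a plain phenylamino arm would test whether the alkoxy group matters at all.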